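The compounds below may be only part of what the source reports. "The series", "measured", "known", "first", "only" and "open" are said of these compounds alone.

Measured in an assay on isolated protein for binding affinity to vitamin D3 receptor (Homo sapiens), with a stated time of 4 h; on this read-out higher numbers stand for weaker inhibition and lower numbers for stronger inhibition:
compound 1 `CCN(CC)CCCNC(=O)c1ccc(C(CC)(CC)c2ccc(OCC(=O)C(C)(C)C)c(C)c2)n1CC` gives 863 nM
compound 2 `CCN(CC)CCCNC(=O)c1ccc(C(CC)(CC)c2ccc(OCC(O)C(C)(C)C)c(C)c2)n1CC` gives 71.1 nM

Compound 2 has the lower of the two numbers, separated from compound 1 by a 12-fold lower number from compound 1 to compound 2 (1.08 log units; beyond the scatter). Compound 3 `CCn1c(C(=O)NCCN)ccc1C(CC)(CC)c1ccc(OCC(O)C(C)(C)C)c(C)c1` is to be measured in this assay. It differs from compound 2 by amino in place of (diethylamino)methyl on a saturated chain carbon, two bonds along the chain from an amide-type nitrogen. For the measured compounds named here, the single measured step concerns the chain bound to an oxygen on the aromatic ring, not the amide-type nitrogen side, so no measured step bears on this change. With nothing comparable to draw on, the expected shift is none beyond the scatter, a 1.1-fold higher number from compound 2 to compound 3 (0.05 log units; within the scatter). Compound 3 is estimated at 80 nM, with a range from 30 nM to 250 nM.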

Compound 3, half-maximal inhibitory concentration: 194 nM
Compound 3: middle estimate off by 2.4-fold (0.38 log units), on the low side; the measured number falls inside the stated range.
By their numbers in this assay, from the lowest: compound 2; then compound 3; then compound 1.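

The amide-side chain also moves the read-out: 3-(diethylamino)propyl to 2-aminoethyl gives a 2.7-fold higher number from compound 2 to compound 3 (0.44 log units; beyond the scatter) in this assay, a smaller step than a 12-fold lower number from compound 1 to compound 2 (1.08 log units; beyond the scatter) on the chain bound to the oxygen. This single change both shortens the chain and removes the ethyl groups from the amine, so the two contributions cannot be separated. No available data account for the shift.

An aminopropyl chain or a 2-(diethylamino)ethyl chain would separate chain length from amine substitution. Going by these compounds, whether a dimethylamino end behaves like either terminal amine remains open.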